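Acylated thioglycoside amides: acyl chain variation at the amide

The source may hold more compounds than are shown below. What is called first, only, known or untested is meant among the compounds shown, and "the series" means these compounds.

Measured compounds:
compound 1, `CCCCCCCCCCCCCCCCCC(=O)Nc1nnc(S[C@@H]2O[C@H](COC(C)=O)[C@H](OC(C)=O)[C@H](OC(C)=O)[C@H]2OC(C)=O)s1` — 31200 nM
compound 2, `CCCCCCCCCCCCCCCCCC(=O)Nc1nnc(S[C@@H]2O[C@H](CO)[C@H](O)[C@H](O)[C@H]2O)s1` — "not active" (no number reported)

In a functional assay on DU-145 cells (Homo sapiens) for cytotoxicity, read by MTT assay, with a stated time of 24 h (a lower number here means a stronger inhibitor, a higher number a weaker inhibitor), compound 1 gives 31200 nM. Going by the values given here, compound 2, which carries the free sugar in place of the acetylated one, is reported in this assay as "not active" (no number reported) without a number, so compound 1 holds the only number in the set and cannot be ranked against anything. Compound 3, `CCCCCCCC/C=C\CCCCCCCCCCCC(=O)Nc1nnc(S[C@@H]2O[C@H](COC(C)=O)[C@H](OC(C)=O)[C@H](OC(C)=O)[C@H]2OC(C)=O)s1`, keeps the acetylated sugar and the core of compound 1 and alters only the acyl chain: dec-1-en-1-yl in place of hexyl on a saturated chain carbon, ten or more bonds along the chain from a carbonyl carbon. Among the compounds with values here, no step between two measured compounds bears on this change; the only comparison available, compound 1 against compound 2, concerns the sugar and not the chain. The step of a 1.1-fold lower number from compound 1 to compound 3 (0.05 log units; within the scatter) is therefore expected to stay within the scatter, with no direction assumed. Compound 3 is estimated at 28000 nM, with a range from 9000 nM to 90000 nM.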

Compound 3, half-maximal inhibitory concentration: 28400 nM
Estimate against measurement, compound 3: 1.0-fold (0.01 log units) below, within the range that was stated.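

In this assay, dec-1-en-1-yl in place of hexyl on a saturated chain carbon, ten or more bonds along the chain from a carbonyl carbon, gives a 1.1-fold lower number from compound 1 to compound 3 (0.04 log units; within the scatter). Going by these compounds alone, this is the first reading on the acyl chain itself, as the earlier comparison concerned only the sugar: with the acetylated sugar and the shared core kept, hexyl and dec-1-en-1-yl at this place are not told apart in this assay. No measurement on hand accounts for this result.

Open, as far as these compounds go, is whether an amine or a carboxylic acid at the end of the chain, or a much shorter acyl chain, would separate from compound 1 beyond the scatter. Also open, from the compounds shown here alone, is whether dec-1-en-1-yl would give a number on the free sugar of compound 2.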